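A few compounds are considered here, and "the series" means these few. Any claim that something is new, unique, unknown or untested is made for them only; others in the source may bear on it.

In an ADME assay on Vero cells (Chlorocebus sabaeus) for cytotoxicity, read by sulforhodamine B assay, with a stated time of 3 days (a higher number here means that more compound is tolerated, a lower number that less compound is tolerated), compound 1 (`COc1ccc(NC(=O)C2=C(C)NC(=O)NC2c2ccccc2)cc1`) gives 225 ug/mL and compound 2 (`COc1ccc(NC(=O)C2=C(C)NC(=S)NC2c2ccccc2)cc1`) gives 15 ug/mL. Compound 2 therefore holds the lower of the two numbers, and its gap to compound 1 lies beyond the scatter. Compound 3 (`COc1ccc(NC(=O)C2=C(C)NC(=S)NC2c2cccc([N+](=O)[O-])c2)cc1`) keeps the core of compound 2 and carries nitro in place of hydrogen on an aromatic carbon, the change from phenyl to 3-nitrophenyl: nitro in place of hydrogen on an aromatic carbon. For the measured compounds named here, no measured pair shows this change, so the data give no direct size for it. In this assay no shift beyond the scatter is expected, with only a slight lean toward less compound being tolerated. The expected change is a 1.3-fold lower number from compound 2 to compound 3 (0.10 log units; within the scatter). For compound 3 the estimate is 12 ug/mL, with an expected range of 4 ug/mL to 40 ug/mL.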

Compound 3, half-maximal cytotoxic concentration: 80 ug/mL
Compound 3: middle estimate off by 6.7-fold (0.82 log units), on the low side; measured number above the stated range.
By their numbers in this assay, from the lowest: compound 2; then compound 3; then compound 1.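

Against the core of compound 2, the change from phenyl to 3-nitrophenyl is the first reading at this position in this assay, and it gives a 5.3-fold higher number from compound 2 to compound 3 (0.73 log units; beyond the scatter). This position on the aromatic ring therefore accepts a nitro group, and the number responds to the change, rising rather than falling. That rests on this one pair, and nothing measured here accounts for the rise.

From the compounds shown here alone, whether the rise belongs to nitro itself or would also follow other groups at this position stays open; an amine, a carboxylic acid or a methoxy group there would help to separate the two. Also open, going by these compounds, is whether phenyl to 3-nitrophenyl moves the number the same way on the core of compound 1, which already stands higher at 225 ug/mL.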